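This account rests on a few compounds, and the source may have more. Where it says the series, first, only, none or still open, it means among the compounds named here.

Three compounds built on one shared core have been examined in a functional assay on CHO cells with adenosine receptor A1 (Homo sapiens) as the target, read by cAMP accumulation and immunoassay, with a stated time of 6 min, tested at 0.1 uM; a higher number here means a weaker effect of the compound at the concentration tested, a lower number a stronger effect. Compound 1 `Nc1scc(CN2CCN(c3ccc(OC(F)(F)F)cc3)CC2)c1C(=O)c1ccc(Cl)cc1` gives -13% in this assay. Compound 2 `Nc1scc(CN2CCN(c3ccc(C(F)(F)F)cc3)CC2)c1C(=O)c1cccc(C(F)(F)F)c1` gives -11%, and compound 3 `Nc1scc(CN2CCN(c3cccc(F)c3)CC2)c1C(=O)c1cccc(C(F)(F)F)c1` gives -12%. Compound 1 therefore sits alongside compound 3, its nearest neighbour, and compound 2, its furthest; both gaps lie within the usual scatter of the measurement, so the three compounds cannot be told apart on these numbers, and all show only a small effect at the concentration tested.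

Compound 4 `Nc1scc(CN2CCN(c3c(F)cc(F)cc3F)CC2)c1C(=O)c1ccc(Cl)cc1` has not yet been measured in this assay. It differs from compound 1 in one place: 2,4,6-trifluorophenyl in place of 4-(trifluoromethoxy)phenyl on an amine nitrogen in a ring. For the measured compounds named here, only one measured step bears on this kind of change, since it also exchanges the aromatic group that sits on the amine nitrogen in the ring: a number 1 percentage points lower from compound 2 to compound 3 (within the scatter). That step stayed within the scatter, which gives no ground to expect that a further exchange of this aromatic group moves the number beyond the scatter in either direction.

For compound 4 the expected step is therefore a number 1 percentage points higher from compound 1 to compound 4 (within the scatter), with no movement beyond the scatter. Compound 4 is estimated to give -12% in this assay, in the expected range from -22% to 0%.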

Compound 4, a percentage reported as activity, at one concentration (the size of the read-out at that concentration, not a potency): -3.9%
For compound 4 the middle estimate is 8.1 percentage points below the measured one; the range from low to high includes it.
By their numbers in this assay, from the lowest: compounds 1, 3, 2 and 4 (each within the scatter of the next).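

In this assay, for the compounds shown here, the exchange of 4-(trifluoromethoxy)phenyl for 2,4,6-trifluorophenyl on the amine nitrogen in the ring gives a number 9.1 percentage points higher from compound 1 to compound 4 (within the scatter), and this is the first step at this place measured on the core of compound 1. Together with a number 1 percentage points lower from compound 2 to compound 3 (within the scatter), which was measured on a core with a different group on the carbonyl, it shows that two different exchanges of this aromatic group, on two cores, both stay within the scatter, and neither of the two steps goes against that. The entering group also holds no oxygen, yet that difference brings no change that can be told apart from the scatter, and nothing available here gives a reason for the size of the step.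

The compounds shown leave open whether a pyridine ring, or a non-aromatic group such as methyl or cyclohexyl, on this nitrogen would move the number beyond the scatter. They also leave open how the compounds compare in potency, since each read-out comes from one concentration only.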